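Side-chain swap on the oxazolidinone and cytotoxicity

The source may report more compounds than this note shows. Statements on the series, on what has been measured and on what is new or still open speak of the compounds shown alone.

Measured so far in an ADME assay on HEK293-A cells (Homo sapiens) for cytotoxicity, read by MTT assay, with a stated time of 48 h; on this read-out lower numbers stand for stronger inhibition and higher numbers for weaker inhibition:
Compound 1 `CN1CCN(C[C@H]2CN(c3ccc(-n4cc(-c5ccccn5)cn4)c(F)c3)C(=O)O2)CC1` gives 70 ug/mL.
Compound 2 `COC(=O)CC1CCN(C[C@H]2CN(c3ccc(-n4cc(-c5ccccn5)cn4)c(F)c3)C(=O)O2)CC1` gives 224 ug/mL.
Compound 3 `O=C1CSC(=O)N1C[C@H]1CN(c2ccc(-n3cc(-c4ccccn4)cn3)c(F)c2)C(=O)O1` gives 283 ug/mL.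

Among these three, compound 3 carries the highest number: the step of a 1.3-fold higher number from compound 2 to compound 3 (0.10 log units; within the scatter) lies within the scatter, while the step of a 4.0-fold higher number from compound 1 to compound 3 (0.61 log units; beyond the scatter) lies beyond it. Compound 4 `CN(C)S(=O)(=O)NC[C@H]1CN(c2ccc(-n3cc(-c4ccccn4)cn3)c(F)c2)C(=O)O1` is the next compound to be measured. Its structure differs from compound 3 at a single place: (dimethylsulfamoyl)amino in place of 2,4-dioxo-1,3-thiazolidin-3-yl on a saturated chain carbon bound to a saturated ring carbon.

Among the compounds with values here, two measured steps bear on this change, since both replace the group on the saturated chain carbon bound to a saturated ring carbon. The step of a 3.2-fold higher number from compound 1 to compound 2 (0.51 log units; beyond the scatter) and the step of a 4.0-fold higher number from compound 1 to compound 3 (0.61 log units; beyond the scatter) were modest, whereas the step of a 1.3-fold higher number from compound 2 to compound 3 (0.10 log units; within the scatter) showed no difference beyond the scatter. Compound 2 and compound 3 thus sit close together, and compound 4 is expected to remain near them. The estimated step of a 1.1-fold lower number from compound 3 to compound 4 (0.05 log units; within the scatter) is expected to stay within the scatter. Compound 4 is therefore estimated at 250 ug/mL, with a range from 120 ug/mL to 500 ug/mL.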

Compound 4, half-maximal inhibitory concentration: 249 ug/mL
Beside the measured number, compound 4's estimate is 1.0-fold (0.00 log units) above it, and the stated range covers the measured number.
By their numbers in this assay, from the lowest: compound 1; then compounds 2, 4 and 3 (each within the scatter of the next).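

In this assay, the open-chain (dimethylsulfamoyl)amino group, which has no ring and carries a hydrogen-bond donor, cannot be told apart from the ring-bearing groups of compound 3 and compound 2: the result is a 1.1-fold lower number from compound 3 to compound 4 (0.06 log units; within the scatter) and a 1.1-fold higher number from compound 2 to compound 4 (0.05 log units; within the scatter). On the saturated chain carbon bound to a saturated ring carbon, a ring in the entering group is therefore not needed for a number in this range, and among these four compounds only 4-methylpiperazin-1-yl stands apart, with a 3.6-fold higher number from compound 1 to compound 4 (0.55 log units; beyond the scatter). No measurement shown here accounts for this grouping.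

The compounds shown leave open whether the lower number of compound 1 belongs to 4-methylpiperazin-1-yl alone or would also appear with morpholin-4-yl or a plain primary amine at this place. They also leave open how a carboxylic acid or a longer chain would read out on this same carbon.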